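A few compounds are considered here, and "the series" means these few. Any claim that something is new, unique, unknown or untested is made for them only; others in the source may bear on it.

Of the compounds shown here, two of a shared core have been measured in a functional assay on HeLa cells (Homo sapiens) for antiproliferative activity, read by MTT assay, with a stated time of 72 h; a lower number here means a stronger inhibitor, a higher number a weaker inhibitor. Compound 1 `O=c1[nH]c(=O)n(CCC(CO)CO)cc1-c1cccs1` gives 7800 nM. Compound 2 `CC(=O)OCC(CCn1cc(C#Cc2cc(F)cc(F)c2)c(=O)n(C(=O)c2ccccc2)c1=O)COC(C)=O` gives 64500 nM, the higher of the two numbers, so it is the weaker inhibitor of the pair. Compound 3 `CC(=O)OCC(CCn1cc(C#Cc2ccc(Br)cc2)c(=O)n(C(=O)c2ccccc2)c1=O)COC(C)=O` has not yet been measured; it differs from compound 2 in one place: 4-bromophenyl in place of 3,5-difluorophenyl on a triple-bonded carbon. No comparable exchange has been measured here, so no direction is known for it. Compound 3 is therefore expected to stay close to compound 2, with a step of a 1.3-fold lower number from compound 2 to compound 3 (0.11 log units; within the scatter) that need not exceed the scatter. The estimate for compound 3 is 50000 nM, with a range from 15000 nM to 200000 nM.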

Compound 3, half-maximal inhibitory concentration: 47200 nM
Compound 3: the middle estimate sits 1.1-fold (0.03 log units) above what was measured; the measured number falls inside the stated range.
By their numbers in this assay, from the lowest: compound 1; then compounds 3 and 2 (each within the scatter of the next).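

In this assay, 4-bromophenyl in place of 3,5-difluorophenyl on the triple-bonded carbon gives a 1.4-fold lower number from compound 2 to compound 3 (0.14 log units; within the scatter). Among the compounds shown here, this is the first exchange at this position, and the two aryl groups cannot be told apart here, although they differ in the number, kind and placement of their halogen atoms. No measurement at hand explains this result. Going by these compounds, whether a ring carrying an amine or a carboxylic acid would behave the same remains open. On these data alone, compound 1 differs from compound 2 and compound 3 in more than one place, so the source of its separate number also remains open.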